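The source may hold more compounds than are shown below. What is called first, only, known or untested is meant among the compounds shown, and "the series" means these compounds.

Measured compounds:
compound 1 `O=S(=O)(NCCCNc1nccc(-c2c(-c3cccc(F)c3)nc3sccn23)n1)c1ccc(Br)cc1` — 9400 nM
compound 2 `O=S(=O)(NCCNc1nccc(-c2c(-c3cccc(F)c3)nc3sccn23)n1)c1ccc(F)cc1` — 9450 nM
compound 3 `O=S(=O)(NCCCNc1nccc(-c2c(-c3cccc(F)c3)nc3sccn23)n1)c1ccc(Cl)cc1` — 8450 nM

In a functional assay on SK-MEL-28 cells (Homo sapiens) for cytotoxicity, read by MTT assay (on this read-out lower numbers stand for stronger inhibition and higher numbers for weaker inhibition), compound 3 gives the lowest of the three numbers, but its neighbours sit close: a 1.1-fold lower number from compound 1 to compound 3 (0.05 log units; within the scatter) and a 1.1-fold lower number from compound 2 to compound 3 (0.05 log units; within the scatter), both within the scatter. Compound 4 `Cc1ccc(S(=O)(=O)NCCNc2nccc(-c3c(-c4cccc(F)c4)nc4sccn34)n2)cc1` is not yet measured; it differs from compound 3 in one place: ((4-methylphenyl)sulfonyl)amino in place of (((4-chlorophenyl)sulfonyl)amino)methyl on a saturated chain carbon, two bonds along the chain from a nitrogen on an aromatic ring. The shift to the two-carbon chain was already seen in a 1.0-fold higher number from compound 1 to compound 2 (0.00 log units; within the scatter) and in reverse in a 1.1-fold lower number from compound 2 to compound 3 (0.05 log units; within the scatter), and swapping the halogen on the ring gave a 1.1-fold lower number from compound 1 to compound 3 (0.05 log units; within the scatter); none of these moved beyond the scatter. A methyl on that ring has not been tried, so the expectation for compound 4 rests on the flat picture so far, and the estimated step of a 1.1-fold higher number from compound 3 to compound 4 (0.03 log units; within the scatter) is expected to stay within the scatter. Compound 4 is therefore estimated at 9000 nM, within 4500 nM to 18000 nM.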

Compound 4, half-maximal inhibitory concentration: > 20000 nM
Compound 4 ended at the assay's limit (the forecaster's own chance of this, stated with the estimate: 5%); middle value at least 2.2-fold (0.34 log units) away from the limit.
By their numbers in this assay, from the lowest: compounds 3, 1 and 2 (each within the scatter of the next). At a limit, above all of these: compound 4.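

In this assay compound 4 stands at a limit of the assay and not at a number: the limit of > 20000 nM in this assay, at which 1 of the 4 values shown sits. Steps now pass beyond the scatter where none did before, and the simplest is methyl in place of fluoro on an aromatic carbon (an at least 2.1-fold higher number from compound 2 to compound 4 (0.32 log units; beyond the scatter)); the two that also alter the chain point the same way (an at least 2.3-fold higher number from compound 3 to compound 4 (0.37 log units; beyond the scatter)) (an at least 2.1-fold higher number from compound 1 to compound 4 (0.32 log units; beyond the scatter)). So the group on that aromatic carbon can matter, although fluoro, chloro and bromo compounds stayed within the scatter of one another.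

Going by these compounds, whether a methoxy or a trifluoromethyl there would side with methyl or with the halogens stays open. So does how far compound 4 lies past its limit.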